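Exchanging a fluorophenyl for an aminophenyl on a shared core

The source may report more compounds than this note shows. Statements on the series, on what has been measured and on what is new or still open speak of the compounds shown alone.

Three compounds from one series share a fused core carrying two ester groups and an aryl group. Compound 1 `COC(=O)CC1C(C(=O)OC)=C(N)Oc2ccc(-c3cc(OC)cc(OC)c3)cc21` and compound 2 `CCCOC(=O)CC1C(C(=O)OCCC)=C(N)Oc2ccc(-c3cc(OC)cc(OC)c3)cc21` differ in the length of their ester chains; compound 3 `CCOC(=O)CC1C(C(=O)OCC)=C(N)Oc2ccc(-c3ccccc3F)cc21` carries shorter chains and a different aryl group. In a functional assay on HL-60 cells (Homo sapiens) for cytotoxicity, read by CellTiter-Blue, with a stated time of 48 h (a lower number here means a stronger inhibitor, a higher number a weaker inhibitor), compound 1 gives 2420 nM and compound 2 gives 7600 nM. Compound 3 gives 73000 nM in this assay, the highest of the three numbers, and its gaps to compound 2 and to compound 1 both lie beyond the usual scatter.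

Compound 4 `CCOC(=O)CC1C(C(=O)OCC)=C(N)Oc2ccc(-c3cccc(N)c3)cc21` is not yet measured. It keeps the ester chains of compound 3 and changes only the aryl group: 3-aminophenyl in place of 2-fluorophenyl on an aromatic carbon. Within the data shown here, no pair of measured compounds isolates this kind of change. Compounds 1 and 2 also differ from compound 3 in their ester chains. A moderate move toward a lower number is expected, of the size a 2.4-fold lower number from compound 3 to compound 4 (0.39 log units; beyond the scatter), though a result within the scatter would not surprise. Compound 4 is therefore estimated at 30000 nM, with a likely range from 8000 nM to 120000 nM.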

Compound 4, half-maximal inhibitory concentration: 20200 nM
Compound 4: the middle estimate sits 1.5-fold (0.17 log units) above what was measured; the range from low to high includes it.
By their numbers in this assay, from the lowest: compound 1; then compound 2; then compound 4; then compound 3.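

In this assay, the aryl group can now be judged on its own: with the ester chains held the same, 3-aminophenyl in place of 2-fluorophenyl gives a 3.6-fold lower number from compound 3 to compound 4 (0.56 log units; beyond the scatter). Among these compounds, this is the first comparison that varies this aryl group and nothing else, and it shows that the position responds to such an exchange, with a modest step that still lies beyond the usual scatter. Nothing available explains why the number falls.

On these data alone, the exchange replaces fluorine with an amino group and also changes where the substituent sits on the aryl ring, so the share of each change stays open. The compounds shown also leave open how a plain phenyl group, or a carboxylic acid on that ring, would compare.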